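Amino for Hydrogen on a Chloropurine Core: Cytotoxicity Expectation

This account rests on a few compounds, and the source may have more. Where it says the series, first, only, none or still open, it means among the compounds named here.

Measured compounds:
Compound 1 `ClCc1ccccc1Cn1cnc2c(Cl)nc(Cl)nc21`: "not determined" (no result reported)
Compound 2 `ClCc1ccccc1Cn1cnc2c(Cl)ncnc21`: > 100000 nM
Compound 3 `ClCc1ccccc1Cn1cnc2ncnc(Cl)c21`: > 100000 nM

In a functional assay on SNB-19 cells (Homo sapiens) for cytotoxicity, read by sulforhodamine B assay, with a stated time of 48 h (on this read-out higher numbers stand for lower toxicity in this test and lower numbers for higher toxicity in this test), compound 1 is reported as "not determined" (no result reported). In this assay compound 2 reaches only a limit, > 100000 nM, which is not a number. Compound 3 likewise sits at a limit, > 100000 nM. So compound 2 stands where the other measured value stands, at the limit of the assay, with no single number anywhere to compare it to.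

Compound 4 `Nc1nc(Cl)c2ncn(Cc3ccccc3CCl)c2n1` has not been tested in this assay. It differs from compound 2 in one place: amino in place of hydrogen on an aromatic carbon, the amino group sitting on an aromatic carbon between two ring nitrogen atoms, meta to a chloro group. Among the measured compounds shown here, no measured pair tells how such a change moves this read-out. Given that compound 2 gives > 100000 nM, the expectation is that compound 4 stays close to that limit, with no step beyond the scatter, a step that the limit leaves unreadable from compound 2 to compound 4. Compound 4 is therefore estimated at 120000 nM, within 40000 nM to 400000 nM.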

Compound 4, concentration lethal to 50% of the cells: > 100000 nM
Compound 4: no number, only a limit; the forecaster's own chance of this, stated with the estimate: 75%; the middle value does not contradict the limit.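

In this assay compound 4 gives > 100000 nM, which is a limit and not a number. Compound 2 also sits at a limit, so no step between compound 2 and compound 4 can be read: the limit of > 100000 nM in this assay, at which 3 of the 4 values shown sit.

The compounds shown leave open whether amino in place of hydrogen on an aromatic carbon changes the toxicity at all.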